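Swapping the pyridine for methoxyphenyl on the vinyl arm

This account rests on a few compounds, and the source may have more. Where it says the series, first, only, none or still open, it means among the compounds named here.

The measured compounds, with their read-outs in an assay on cells for inhibition of Ectonucleotide pyrophosphatase/phosphodiesterase family member 1 (Homo sapiens), with a stated time of 60 min, tested at 1 uM; a higher number here means more inhibition at the concentration tested (going by the name of the read-out), a lower number less inhibition:

- compound 1, `COc1cc2nc(/C=C/c3cccnc3)nc(N3CCC(CCNS(N)(=O)=O)CC3)c2cc1OC`, gives 86%
- compound 2, `COc1cc2nc(/C=C/c3ccncc3)nc(N3CCC(CCNS(N)(=O)=O)CC3)c2cc1OC`, gives 79%
- compound 3, `COc1cc2nc(/C=C/c3ccccc3F)nc(N3CCC(CCNS(N)(=O)=O)CC3)c2cc1OC`, gives 78%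

All three share the same core and differ only in the aromatic ring attached to the double-bonded chain carbon. The numbers for compound 2, compound 1 and compound 3 all lie within the usual scatter of one another: the steps of a number 7 percentage points lower from compound 1 to compound 2 (within the scatter), a number 8 percentage points lower from compound 1 to compound 3 (within the scatter) and a number 1 percentage points lower from compound 2 to compound 3 (within the scatter) are each too small to count as real changes, so compound 2 cannot be ranked against its two neighbours.

Compound 4, `COc1ccc(/C=C/c2nc(N3CCC(CCNS(N)(=O)=O)CC3)c3cc(OC)c(OC)cc3n2)cc1`, has not yet been measured. Its difference from compound 2 is 4-methoxyphenyl in place of pyridin-4-yl on a double-bonded chain carbon bound to a double-bonded chain carbon. The measured steps that bear on this change are the three ring swaps already described, and none of them moved the read-out beyond the scatter. On that basis no step beyond the scatter is expected in this assay for this swap either, in neither direction. Compound 4 is therefore expected to give about 78%, with a range from 65% to 90%. This estimate means an expected step of a number 1 percentage points lower from compound 2 to compound 4 (within the scatter).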

Compound 4, a percentage reported as inhibition, at one concentration (the size of the read-out at that concentration, not a potency): 66%
The estimate for compound 4 lay 12 percentage points above the measured number, within the range that was stated.
By their numbers in this assay, from the lowest: compound 4; then compounds 3, 2 and 1 (each within the scatter of the next).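

In this assay, within the data shown here, the ring on the double-bonded chain carbon is not freely interchangeable: 4-methoxyphenyl is the first ring here to take the read-out beyond the scatter, whichever earlier compound it is compared with (a number 13 percentage points lower from compound 2 to compound 4 (beyond the scatter)) (a number 12 percentage points lower from compound 3 to compound 4 (beyond the scatter)) (a number 20 percentage points lower from compound 1 to compound 4 (beyond the scatter)). Losing the ring nitrogen cannot be enough on its own to explain this, since compound 3 also carries a ring of carbon only and stays within the scatter of compound 1 and compound 2. Nothing available explains why this swap lowers the read-out.

From the compounds shown here alone, it remains open whether the methoxy group itself goes with the lower number, which an unsubstituted phenyl ring would help to test. A 4-hydroxyphenyl or 4-aminophenyl ring at this place could show how much the group on the ring matters.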